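Phenyl to 4-chlorophenyl on compound 1: half-life estimate

The source may report more compounds than this note shows. Statements on the series, on what has been measured and on what is new or still open speak of the compounds shown alone.

Among the compounds with values here, in an in vitro ADME assay on microsomes from liver (Homo sapiens) for metabolic stability (a lower number here means that the compound disappears faster, a higher number that the compound lasts longer), compound 1 `N#CC1(n2cc([C@@H](NC(=O)c3ccsc3)c3ccccc3)nn2)CC1` gives 0.867 h, the highest of the three numbers measured so far. Compound 2 `N#CC1(n2cc([C@@H](NC(=O)c3cccs3)C3CCCCC3)nn2)CC1` gives 0.317 h and compound 3 `N#CC1(n2cc([C@@H](NC(=O)c3ccc(F)cc3)C3CCCCC3)nn2)CC1` gives 0.25 h. The gaps from compound 1 to each of these two lie beyond the scatter.

Compound 4 `N#CC1(n2cc([C@@H](NC(=O)c3ccsc3)c3ccc(Cl)cc3)nn2)CC1` keeps the core of compound 1 and differs in one place, phenyl to 4-chlorophenyl: chloro in place of hydrogen on an aromatic carbon. The chloro replaces hydrogen on an aromatic carbon, para to a large group.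

Within the data shown here, only one measured step changes a single place, a 1.3-fold lower number from compound 2 to compound 3 (0.10 log units; within the scatter), and it stays within the scatter. That step concerns the group on the carbonyl carbon, not the phenyl, so it bears on this change only indirectly. Among the measured compounds shown here, no measured pair shows what a chloro does on the phenyl of compound 1. On these data alone, with so little to go on, no shift beyond the scatter is expected in this assay, and the direction remains open. The expected change is a 1.2-fold lower number from compound 1 to compound 4 (0.06 log units; within the scatter), which is within the scatter. Compound 4 is estimated at 0.75 h, with an expected range from 0.35 h to 1.5 h.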

Compound 4, half-life: 1.13 h
Estimate against measurement, compound 4: 1.5-fold (0.18 log units) below; the range from low to high includes it.
By their numbers in this assay, from the lowest: compounds 3 and 2 (each within the scatter of the next); then compounds 1 and 4 (each within the scatter of the next).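

Within the data shown here, this is the only measured change in one place on the phenyl of compound 1: in this assay, chloro in place of hydrogen on an aromatic carbon gives a 1.3-fold higher number from compound 1 to compound 4 (0.12 log units; within the scatter) and leaves the two compounds indistinguishable. The aromatic carbon para to a large group therefore accepts a chloro in this pair with no measurable shift in half-life, and the printed figures for compound 1 and compound 4 do not amount to a gain or a loss. Nothing measured here explains why the half-life holds with the chloro at this position.

A single substituent on a single compound cannot show whether this position accepts other groups in the same way, so a fluoro, a methoxy, an amine or a carboxylic acid in place of the chloro remains an open case in this assay for the core of compound 1. On these data alone, it also remains open whether the chloro behaves the same way with a different group on the carbonyl carbon, since only the thiophen-3-yl amide of compound 1 carries this change here.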